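A few compounds are considered here, and "the series" means these few. Any claim that something is new, unique, unknown or untested is made for them only; others in the source may bear on it.

Working notes on the series.

Three compounds share a core and differ only in the aryl group on the ring. Compound 1 `Cc1cc(O)c(C(C)C)cc1-c1cc(-c2ccccc2)c(C#N)c(=O)[nH]1` gives 58% in a functional assay for inhibition, tested at 80 ug/mL; on this read-out lower numbers stand for a weaker effect and higher numbers for a stronger effect at the one concentration tested. Compound 2 `COc1ccc(-c2cc(-c3cc(C(C)C)c(O)cc3C)[nH]c(=O)c2C#N)c(OC)c1` gives 55% in this assay, and compound 3 `COc1cc(OC)c(-c2cc(-c3cc(C(C)C)c(O)cc3C)[nH]c(=O)c2C#N)c(OC)c1` gives 79%. On these numbers compound 2 stands lowest of the three, with compound 1 nearest and compound 3 furthest: the step of a number 3 percentage points lower from compound 1 to compound 2 (within the scatter) and the step of a number 24 percentage points higher from compound 2 to compound 3 (beyond the scatter).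

Compound 4 `Cc1cc(O)c(C(C)C)cc1-c1cc(-c2ccco2)c(C#N)c(=O)[nH]1` has not been measured. It differs from compound 2 in one place: furan-2-yl in place of 2,4-dimethoxyphenyl on an aromatic carbon.

Of the measured steps, the exchange of one aryl group for another at this position is the closer precedent, and there the step of a number 3 percentage points lower from compound 1 to compound 2 (within the scatter) did not move the read-out beyond the scatter. Among the measured compounds shown here, the only change that did, the step of a number 24 percentage points higher from compound 2 to compound 3 (beyond the scatter), added a methoxy to a ring that compound 4 no longer carries, so it offers no direct guide. On this basis the estimated step of no change at the digits printed from compound 2 to compound 4 (within the scatter) is expected to stay within the scatter. Compound 4 is therefore estimated at 55% in this assay, with an expected range from 38% to 72%, the measured value to follow.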

Compound 4, a percentage reported as inhibition, at one concentration (the size of the read-out at that concentration, not a potency): 64%
The estimate for compound 4 lay 9 percentage points below the measured number; measured number inside the range.
By their numbers in this assay, from the lowest: compounds 2, 1 and 4 (each within the scatter of the next); then compound 3.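

In this assay, the position opposite the ring nitrogen holds a five-membered aromatic ring with 1 hetero atom without leaving the scatter: the read-out shows a number 9 percentage points higher from compound 2 to compound 4 (within the scatter) and a number 6 percentage points higher from compound 1 to compound 4 (within the scatter). Until now, only six-membered aromatic rings of carbon had been seen here, so the series now spans two ring sizes at this position, and furan-2-yl, with 5 heavy atoms and 1 hydrogen-bond acceptor, reads like 2,4-dimethoxyphenyl, with 10 heavy atoms and 2 hydrogen-bond acceptors, and like phenyl. No measurement at hand explains this result.

From the compounds shown here alone, what a thiophene-2-yl group, or a phenyl carrying an amine or a carboxylic acid, would give at this position remains open, as does whether methoxy on the furan-2-yl ring would produce anything like a number 24 percentage points higher from compound 2 to compound 3 (beyond the scatter). The read-out also comes from a single concentration, so whether compound 1, compound 2 and compound 4 would show a stronger or weaker effect than one another at any other concentration cannot be told from these numbers.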